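The compounds below may be only part of what the source reports. "The series", "measured", "known", "first", "only" and "open" are said of these compounds alone.

The compounds here share one core and differ in the group attached to the ring carbon that sits next to the ring nitrogen. Compound 1 `CCCCNc1nc(C(F)(F)F)ccc1CNC(=O)C(C)c1ccc(NS(C)(=O)=O)c(F)c1` carries a butylamino group there and, in a functional assay on CHO-K1 cells for antagonist activity at transient receptor potential cation channel subfamily V member 1 (Homo sapiens), read by FLIPR (on this read-out lower numbers stand for stronger inhibition and higher numbers for weaker inhibition), compound 1 gives 293 nM. Compound 2 `CC(C(=O)NCc1ccc(C(F)(F)F)nc1NCc1ccc(Cl)cc1)c1ccc(NS(C)(=O)=O)c(F)c1` replaces the chain with a 4-chlorophenylmethyl group on that nitrogen, and in this assay compound 2 gives 414 nM; the change shows a 1.4-fold higher number from compound 1 to compound 2 (0.15 log units; within the scatter). Compound 3 `C[C@H](C(=O)NCc1ccc(C(F)(F)F)nc1N1CCC[C@H]1CO)c1ccc(NS(C)(=O)=O)c(F)c1` closes the nitrogen into a ring bearing a hydroxymethyl group, and in this assay compound 3 is reported as "not active" (no number reported), so no single number stands for compound 3 and it has no numerical place among the others.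

Compound 4 `C[C@H](C(=O)NCc1ccc(C(F)(F)F)nc1N1CCC(c2ccccc2)CC1)c1ccc(NS(C)(=O)=O)c(F)c1` is the next step: 4-phenylpiperidin-1-yl in place of 2-(hydroxymethyl)pyrrolidin-1-yl on an aromatic carbon. Among the measured compounds shown here, no measured step covers this exchange. For the measured compounds named here, the only measured step, that from compound 1 to compound 2, concerns a different part of the same attachment and lay within the scatter, so it gives little guidance on size or direction. The two acyclic analogues suggest that an active number is possible for a ring-bound group, but compound 3 shows the ring itself can abolish activity. Compound 4 is therefore expected to give roughly 600 nM in this assay, with a wide estimated range from 100 nM to 4000 nM.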

Compound 4, half-maximal inhibitory concentration: 17.4 nM
The estimate for compound 4 lay 34-fold (1.54 log units) above the measured number; the measured number lies below the stated range.
By their numbers in this assay, from the lowest: compound 4; then compounds 1 and 2 (each within the scatter of the next).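

Compound 3 is reported as not active, with no number, so its change to compound 4 cannot be read as a step of any size. The compounds shown leave open whether the phenyl group, the six-membered ring or the loss of the hydroxymethyl group goes with the activity of compound 4. No measurement shown here explains this result.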